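Working notes: the aryl change from compound 2 to compound 4

The source may hold more compounds than are shown below. What is called first, only, known or untested is meant among the compounds shown, and "the series" means these compounds.

Of the compounds shown here, three sharing one core have been measured in a functional assay on HCT-116 cells (Homo sapiens) for antiproliferative activity, read by MTT assay, with a stated time of 72 h; a lower number here means a stronger inhibitor, a higher number a weaker inhibitor. Compound 1 `Nc1nc(N)c2cc(CSC(=S)N3CCN(c4ccccc4)CC3)ccc2n1` gives 4120 nM, compound 3 `Nc1nc(N)c2cc(CSC(=S)N3CCN(c4ccc(F)cc4F)CC3)ccc2n1` gives 5150 nM, and compound 2 `Cc1ccccc1N1CCN(C(=S)SCc2ccc3nc(N)nc(N)c3c2)CC1` gives 11800 nM. Compound 2 thus has the highest number of the three and is the weakest inhibitor among them, with both gaps beyond the scatter.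

The next compound is compound 4 `CC(=O)c1ccc(N2CCN(C(=S)SCc3ccc4nc(N)nc(N)c4c3)CC2)cc1`. Its difference from compound 2 is 4-acetylphenyl in place of 2-methylphenyl on an amine nitrogen in a ring.

Within the data shown here, three measured steps bear on this change. Adding the methyl gives a 2.9-fold higher number from compound 1 to compound 2 (0.46 log units; beyond the scatter), and exchanging 2-methylphenyl for 2,4-difluorophenyl gives a 2.3-fold lower number from compound 2 to compound 3 (0.36 log units; beyond the scatter). Both are modest. The step between the two compounds without the methyl, a 1.3-fold higher number from compound 1 to compound 3 (0.10 log units; within the scatter), stays within the scatter. In these three compounds, the aryl groups other than 2-methylphenyl give similar numbers. Among the measured compounds shown here, no measured compound carries an acetyl group, so this reading is only a weak guide and the range stays wide.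

A modest step to a lower number is therefore expected, and the estimated step is a 2.1-fold lower number from compound 2 to compound 4 (0.33 log units; beyond the scatter). For compound 4 the estimated value is 5500 nM, with an expected range from 2200 nM to 13000 nM.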

Compound 4, half-maximal inhibitory concentration: 8260 nM
Estimate against measurement, compound 4: 1.5-fold (0.18 log units) below; the range from low to high includes it.
By their numbers in this assay, from the lowest: compounds 1, 3, 4 and 2 (each within the scatter of the next, the first and the last beyond it).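

In this assay, the 4-acetylphenyl group on the amine nitrogen in a ring cannot be told apart from any of the other three aryl groups: the steps are a 1.4-fold lower number from compound 2 to compound 4 (0.15 log units; within the scatter), a 1.6-fold higher number from compound 3 to compound 4 (0.21 log units; within the scatter) and a 2.0-fold higher number from compound 1 to compound 4 (0.30 log units; within the scatter). This position therefore accepts an acetyl group, with its carbonyl and hydrogen-bond acceptor, without a step beyond the scatter, and compound 4 joins neither side of the one clear gap in the series, which separates compound 1 from compound 2. No measurement bears on the reason for this result, and the data offer no explanation of it.

The compounds shown leave open whether the carbonyl itself plays any part, which a 4-(1-hydroxyethyl)phenyl or 4-ethylphenyl group at this place could test against compound 4. They also leave open whether a 4-carboxyphenyl or 4-aminophenyl group would stay within the same narrow band or give the first clear step away from compound 1 other than the one seen with the 2-methylphenyl group of compound 2.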